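Bicyclic amine amides and ketones at the alpha4/beta2 receptor

The compounds below may be only part of what the source reports. "The series", "measured", "known", "first", "only" and "open" are said of these compounds alone.

Measured so far:
- compound 1, `CC(=O)N1CC2CNCC2C1`: 2600 nM
- compound 2, `O=C(c1ccco1)[C@H]1C[C@@H]2CNC[C@@H](C2)C1`: "not determined" (no result reported)

In an assay on SHEP1 cells for agonist activity at Neuronal acetylcholine receptor; alpha4/beta2 (Homo sapiens), read by FLIPR and calcium flux (on this read-out higher numbers stand for an effect only at larger amounts of compound and lower numbers for an effect already at smaller amounts), compound 1 gives 2600 nM. Going by the values given here, for compound 2 this assay gives "not determined" (no result reported), so compound 2 stands on no number at all; the only number belongs to compound 1, which carries a different core.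

Compound 3, `CCCNC(=O)[C@H]1C[C@@H]2CNC[C@@H](C2)C1`, differs from compound 2 by propylamino in place of furan-2-yl on a carbonyl carbon. Among the compounds with values here, no step between measured compounds is known that bears on this change, and the starting point itself is unmeasured. Any expectation therefore rests on compound 1 alone, whose 2600 nM is the sole anchor for a carbonyl substituent on a saturated bicyclic diamine. No step beyond the scatter can be predicted in either direction. Compound 3 is estimated at 3000 nM, with a range from 400 nM to 25000 nM, and a real chance that only a limit is reported.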

Compound 3, half-maximal effective concentration: 2400 nM
Compound 3: the middle estimate sits 1.3-fold (0.10 log units) above what was measured, and the stated range covers the measured number.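

No step can be read between compound 2 and compound 3, as compound 2 stands at "not determined" (no result reported). The compounds shown leave open whether propylamino in place of furan-2-yl on the carbonyl carbon shifts the read-out at all. Nothing shown bears on the result for compound 3.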